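Removing One Methoxy Group on the Way to Compound 3

The compounds below may be only part of what the source reports. "The series", "measured", "known", "first", "only" and "open" are said of these compounds alone.

Compound 1 `COc1ccc(-c2cc(/C=C/C(=O)c3ccc(N)cc3)[nH]n2)cc1`: -95%
Compound 2 `COc1cc(-c2cc(/C=C/C(=O)c3ccc(N)cc3)[nH]n2)cc(OC)c1OC`: -93%

Both were measured in a functional assay on UACC-257 cells (Homo sapiens) for cytotoxicity, read by sulforhodamine B assay, with a stated time of 48 h, tested at 100 uM; a lower number here means a stronger effect, a higher number a weaker effect of the compound at the concentration tested. Compound 2 holds the higher of the two numbers, but compound 1 sits within the scatter of it, so the two cannot be told apart. Compound 3 `COc1ccc(-c2cc(/C=C/C(=O)c3ccc(N)cc3)[nH]n2)cc1OC` awaits measurement in this assay. It differs from compound 2 by hydrogen in place of methoxy on an aromatic carbon. Going by the values given here, no measured pair shows what this change does; because compound 1 gives -95% and compound 2 gives -93%, the shared core seems to carry the effect. The expected step is no change at the digits printed from compound 2 to compound 3 (within the scatter), none beyond the scatter. Compound 3 is estimated at -93%, between -100% and -80%.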

Compound 3, a percentage reported as activity, at one concentration (the size of the read-out at that concentration, not a potency): -96%
For compound 3 the middle estimate is 3 percentage points above the measured one; measured number inside the range.
By their numbers in this assay, from the lowest: compounds 3, 1 and 2 (each within the scatter of the next).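

In this assay, the step for losing the methoxy group is a number 3 percentage points lower from compound 2 to compound 3 (within the scatter), and the step for adding a methoxy group to the simpler compound is a number 1 percentage points lower from compound 1 to compound 3 (within the scatter). Going by these compounds alone, these are the first direct one-place comparisons, and they show that hydrogen or methoxy on this aromatic carbon, ortho to a methoxy group, makes no readable difference. Nothing available explains this result.

From the compounds shown here alone, whether an amine or a carboxylic acid on this carbon would move the number beyond the scatter remains open. The read-out is also the size of the effect at one concentration, so these numbers describe the effect of these compounds at that concentration only.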